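Swapping a short chain for a phenoxy ring on the shared core

The source may hold more compounds than are shown below. What is called first, only, known or untested is meant among the compounds shown, and "the series" means these compounds.

In a functional assay for inhibition of sodium/hydrogen exchanger (Oryctolagus cuniculus) (on this read-out lower numbers stand for stronger inhibition and higher numbers for weaker inhibition), compound 3 `CCSc1cc(C)c(C(=O)N=C(N)N)cc1S(C)(=O)=O` gives 5.9 nM. Its number is the lowest of the three shown, though compound 1 `CCC(C)c1cc(C)c(C(=O)N=C(N)N)cc1S(C)(=O)=O` with 8 nM sits within the scatter of it, while compound 2 `Cc1cc(-c2cc(Cl)cc(Cl)c2)c(S(C)(=O)=O)cc1C(=O)N=C(N)N` with 130 nM lies far above. The pair of steps that carry an aromatic ring on or off this position are the ones that matter: a 16-fold higher number from compound 1 to compound 2 (1.21 log units; beyond the scatter) and a 22-fold lower number from compound 2 to compound 3 (1.34 log units; beyond the scatter); the step of a 1.4-fold lower number from compound 1 to compound 3 (0.13 log units; within the scatter) shows that the two chains behave alike.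

Compound 4 `Cc1cc(Oc2ccccc2)c(S(C)(=O)=O)cc1C(=O)N=C(N)N` differs from compound 3 in one place: phenoxy in place of ethylsulfanyl on an aromatic carbon. Here a ring without chlorine atoms enters, and the ring is joined through an oxygen rather than directly, so the precedent is only partly matched. Still, both aryl-bearing cases seen so far point the same way, and compound 4 is therefore expected to show a clearly higher number in this assay, a 10-fold higher number from compound 3 to compound 4 (1.01 log units; beyond the scatter). The estimate for compound 4 is 60 nM, with a range from 15 nM to 250 nM.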

Compound 4, half-maximal inhibitory concentration: 10 nM
For compound 4 the middle estimate is 6.0-fold (0.78 log units) above the measured one; the whole stated range lies above it.
By their numbers in this assay, from the lowest: compounds 3, 1 and 4 (each within the scatter of the next); then compound 2.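

An aromatic ring at this position does not by itself weaken inhibition in this assay: phenoxy falls level with both chains, with a 1.7-fold higher number from compound 3 to compound 4 (0.23 log units; within the scatter) and a 1.3-fold higher number from compound 1 to compound 4 (0.10 log units; within the scatter). The high number seen with 3,5-dichlorophenyl therefore does not extend to every aromatic ring, as shown by a 13-fold lower number from compound 2 to compound 4 (1.11 log units; beyond the scatter). That single swap removes the chlorine atoms and adds the oxygen link together, and nothing available explains the gap.

The compounds shown leave open whether the chlorine atoms, the direct attachment of the ring or both set the gap, a question that a plain phenyl group and a 3,5-dichlorophenoxy group could separate. From the compounds shown here alone, it also remains open how other groups at this position, such as an amine or a longer chain, would behave.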